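The compounds below may be only part of what the source reports. "The series", "measured", "known", "first", "only" and "open" are said of these compounds alone.

Measured so far:
compound 1 `COc1ccc(C(=O)NO)cc1NCc1ccc(OCCCCC(=O)Nc2ccc3c(c2)cc(C)c(=O)n3C)cc1`: 50% in an assay on isolated protein for inhibition of protein deacetylase HDAC6 (Homo sapiens), read by fluorescence, with a stated time of 90 min, tested at 1 uM; a higher number here means a stronger effect of the compound at the concentration tested, a lower number a weaker effect
compound 2 `Cc1cc2cc(NCc3cc(C(=O)NO)ccc3Cl)ccc2n(C)c1=O`: 28% in this assay

Of these two numbers, compound 2 holds the lower one; compound 1 sits higher by a gap beyond the scatter. The step to compound 3 `COc1ccc(C(=O)NO)cc1CNc1ccc2c(c1)cc(C)c(=O)n2C` changes a single group: methoxy in place of chloro on an aromatic carbon. Within the data shown here, no measured pair shows this change on its own, so its effect is uncertain; a small rise is expected, possibly no larger than the scatter. Compound 3 is estimated at 35%, between 15% and 60%, which means an expected step of a number 7 percentage points higher from compound 2 to compound 3 (within the scatter).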

Compound 3, a percentage reported as inhibition, at one concentration (the size of the read-out at that concentration, not a potency): 40%
For compound 3 the middle estimate is 5 percentage points below the measured one; the measured number falls inside the stated range.
By their numbers in this assay, from the lowest: compound 2; then compounds 3 and 1 (each within the scatter of the next).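

In this assay, among these compounds, methoxy in place of chloro gives a number 12 percentage points higher from compound 2 to compound 3 (beyond the scatter) on the aromatic carbon para to a hydroxycarbamoyl group, the first change in a single place. The read-out therefore responds to the group on this carbon, although the step is modest. No measurement here gives a reason for the step.

On these data alone, whether a plain hydrogen, an amine or a carboxylic acid on this carbon would give a higher or lower number remains open. So does whether the same exchange would give a similar step on a different core.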